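The source may hold more compounds than are shown below. What is called first, only, known or untested is meant among the compounds shown, and "the series" means these compounds.

Measured compounds in a functional assay on MOLT-4 cells (Homo sapiens) for cytotoxicity, with a stated time of 72 h; on this read-out lower numbers stand for stronger inhibition and higher numbers for weaker inhibition:
compound 1, `O=C1/C(=C/c2ccc(F)cc2)CCC/C1=C\c1ccc([N+](=O)[O-])cc1`: 17100 nM
compound 2, `O=C1/C(=C/c2ccc(Cl)cc2)CCC/C1=C\c1ccc([N+](=O)[O-])cc1`: 9120 nM
compound 3, `CN(C)c1ccc(/C=C2\CCC/C(=C\c3ccc([N+](=O)[O-])cc3)C2=O)cc1`: > 500000 nM, a limit of the assay rather than a number

Within the data shown here, compound 3 therefore has no measured value of its own; it is the single compound sitting at the limit of > 500000 nM in this assay, at which 1 of the 3 values shown sits. Compound 4, `COc1ccc(/C=C2\CCC/C(=C\c3ccc([N+](=O)[O-])cc3)C2=O)cc1`, differs from compound 3 by methoxy in place of dimethylamino on an aromatic carbon.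

Among the measured compounds shown here, two measured steps bear on this change, both leading into the dimethylamino compound: an at least 29-fold higher number from compound 1 to compound 3 (1.46 log units; beyond the scatter) and an at least 54-fold higher number from compound 2 to compound 3 (1.73 log units; beyond the scatter). Both are large and both run toward weaker inhibition, ending at the limit. For the measured compounds named here, the step from compound 3 to compound 4 removes the dimethylamino group, so the direction is expected to reverse, but no measured compound carries a methoxy group, and the size of the return is not fixed by the data; only a lower bound for the move from the limit can be expected.

Compound 4 is expected to give 60000 nM in this assay, within 10000 nM to 500000 nM. This estimate amounts to an expected at least 8.3-fold lower number from compound 3 to compound 4 (0.92 log units; beyond the scatter).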

Compound 4, half-maximal inhibitory concentration: 300000 nM
Beside the measured number, compound 4's estimate is 5.0-fold (0.70 log units) below it, and the stated range covers the measured number.
By their numbers in this assay, from the lowest: compounds 2 and 1 (each within the scatter of the next); then compound 4. At a limit, above all of these: compound 3.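

In this assay, a second group on this aromatic carbon, para to a large group, now gives weak inhibition relative to the two halogen compounds, so this is no longer seen with dimethylamino alone: a 33-fold higher number from compound 2 to compound 4 (1.52 log units; beyond the scatter) and an 18-fold higher number from compound 1 to compound 4 (1.24 log units; beyond the scatter). The change from dimethylamino to methoxy itself reads only as an at least 1.6-fold lower number from compound 3 to compound 4 (0.22 log units; that floor lies within the scatter). The entry for compound 3 is a limit and not a number: the limit of > 500000 nM in this assay, at which 1 of the 4 values shown sits.

Still open, from the compounds shown here alone, is where a hydroxy group, a primary amine or a trifluoromethyl group on this aromatic carbon would fall relative to the halogen compounds and compound 4. Also open, going by these compounds, is whether the gap between methoxy and the halogens persists when the nitro group of the shared core gives way to a nitrile.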